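This account rests on a few compounds, and the source may have more. Where it says the series, first, only, none or still open, it means among the compounds named here.

Working notes on the series. Compound 1 `Cc1cccc(COc2ccc(/C=C/C(/C=C/c3ccccn3)=N/Oc3ncnc4ccccc34)cc2)c1` and compound 2 `Clc1ccc(COc2ccc(/C=C/C(/C=C/c3ccccn3)=N/Oc3ncnc4ccccc34)cc2)cc1` share one core and differ only in the group on the saturated chain carbon bound to an oxygen on an aromatic ring. In a functional assay on SMMC-7721 cells (Homo sapiens) for inhibition, read by MTT assay, with a stated time of 72 h, tested at 10 uM (on this read-out lower numbers stand for a weaker effect and higher numbers for a stronger effect at the one concentration tested), compound 1 gives 97.5%. In this assay compound 2 gives 94.4%. The single measured step, a number 3.1 percentage points lower from compound 1 to compound 2 (within the scatter), is within the scatter, so compound 2 stands within the scatter of compound 1 and the two numbers do not separate; on the numbers shown compound 2 is simply one of two closely matched readings.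

Compound 3 `Clc1ccccc1COc1ccc(/C=C/C(/C=C/c2ccccn2)=N/Oc2ncnc3ccccc23)cc1` is the next compound. Its difference from compound 2 is 2-chlorophenyl in place of 4-chlorophenyl on a saturated chain carbon bound to an oxygen on an aromatic ring. Going by the values given here, no measured step moves the chlorine around the ring; the only step on record exchanged one ring for another at that place and stayed within the scatter, and that is the sole guide. On that basis the step expected in this assay is a number 1.4 percentage points lower from compound 2 to compound 3 (within the scatter), none beyond the scatter in either direction. Compound 3 is therefore estimated at 93% in this assay, with a range from 80% to 100%.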

Compound 3, a percentage reported as inhibition, at one concentration (the size of the read-out at that concentration, not a potency): 96.9%
Compound 3: the middle estimate sits 3.9 percentage points below what was measured; measured number inside the range.
By their numbers in this assay, from the lowest: compounds 2, 3 and 1 (each within the scatter of the next).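

Going by these compounds alone, exchanging 4-chlorophenyl for 2-chlorophenyl on a saturated chain carbon bound to an oxygen on an aromatic ring is the first change on record that keeps the same atoms and only moves the chlorine, and in this assay it gives a number 2.5 percentage points higher from compound 2 to compound 3 (within the scatter). Exchanging 3-methylphenyl for 2-chlorophenyl at that place gives a number 0.6 percentage points lower from compound 1 to compound 3 (within the scatter), so the 3-methylphenyl, 4-chlorophenyl and 2-chlorophenyl groups do not separate at all in this set, and moving the chlorine between these two names adds no distinction to what the first step showed. No measured evidence bears on why these three readings stand together.

Going by these compounds, all three compounds carry a substituted phenyl at this place and were read at a single concentration, so it remains open whether they would separate in a potency measurement at lower concentrations. On these data alone, it is also open whether the reading holds with a different kind of group there, such as an amine or a carboxylic acid on the phenyl ring, or a longer chain between the phenyl ring and the oxygen.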